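The source may report more compounds than this note shows. Statements on the series, on what has been measured and on what is new or still open speak of the compounds shown alone.

Compound 1 `O=C(/N=C/c1ccc(F)cc1)Nc1ccc2c(c1)C(=O)C(=O)N2CN1CCCCC1` gives 300 mg/kg in a functional assay on the whole organism (strain Swiss albino) with Mus musculus as the target, with a stated time of 4 h; a lower number here means that less compound is needed, a higher number that more compound is needed for the effect. Compound 2 `O=C(/N=C/c1ccc(Br)cc1)Nc1ccc2c(c1)C(=O)C(=O)N2CN1CCCCC1` gives 300 mg/kg.

Compound 1 stands level with compound 2. For the measured compounds named here, the one measured step bearing on the new change is no change at the digits printed from compound 1 to compound 2 (within the scatter), a swap of one halogen for another on the same aromatic carbon. Compound 3 `COc1ccc(/C=N/C(=O)Nc2ccc3c(c2)C(=O)C(=O)N3CN2CCCCC2)cc1` differs from compound 1 in that position: methoxy in place of fluoro on an aromatic carbon. Since the halogen swap left the minimum effective dose unchanged, no step beyond the scatter is expected here either, though methoxy is not a halogen and the evidence is thin. Compound 3 is estimated at 300 mg/kg, within 150 mg/kg to 600 mg/kg, a step of no change at the digits printed from compound 1 to compound 3 (within the scatter).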

Compound 3, minimum effective dose: 300 mg/kg
Compound 3: the middle estimate sits on the measured number at the digits printed; low and high end bracket the measured number.
By their numbers in this assay, from the lowest: compounds 1, 2 and 3 (each within the scatter of the next).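

In this assay, going from 4-fluorophenyl to 4-methoxyphenyl gives no change at the digits printed from compound 1 to compound 3 (within the scatter), and methoxy in place of bromo gives no change at the digits printed from compound 2 to compound 3 (within the scatter). This position has now taken a group that is not a halogen, one carrying oxygen and a hydrogen-bond acceptor, without separating the three compounds in minimum effective dose. Nothing available offers an explanation for this flat result. An amine, a carboxylic acid or a longer chain at this position remains an open case. Going by these compounds, whether changes elsewhere on the shared core would shift the dose also remains open.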